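The source may report more compounds than this note shows. Statements on the series, on what has been measured and on what is new or still open speak of the compounds shown alone.

Measured compounds:
- compound 1, `CCc1cccc(NC(=O)CN2CCC(c3cccc[n+]3[O-])CC2)c1`: 62%
- compound 2, `Cc1cccc(NC(=O)CN2CCC(c3ccccc3C)CC2)c1`: 43%

Both were tested in a functional assay on HEK293 cells for agonist activity at D(4) dopamine receptor (Homo sapiens), read by FLIPR; a higher number here means a larger maximal response, a lower number a smaller maximal response. Compound 1 stands highest of the two numbers; compound 2 lies beyond the usual scatter below it, but the two differ in more than one place, so the values alone say nothing about which change is responsible.

The step of interest leads from compound 1 to compound 3, `CSc1cccc(NC(=O)CN2CCC(c3cccc[n+]3[O-])CC2)c1`, which has not yet been measured. The change is methylsulfanyl in place of ethyl on an aromatic carbon. The leaving and entering groups each carry the same number of heavy atoms, and they sit on the same aromatic carbon of the shared core. For the measured compounds named here, no pair of measured compounds shows this change, so its effect is unknown from the data here. With nothing to point in either direction, the expected step in this assay from compound 1 to compound 3 is a number 4 percentage points lower from compound 1 to compound 3 (within the scatter), small and within the scatter. Compound 3 is therefore estimated to give 58%, between 40% and 76%.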

Compound 3, largest response reached (reported as efficacy), in percent of the reference or control that the assay uses: 56%
The estimate for compound 3 lay 2 percentage points above the measured number; low and high end bracket the measured number.
By their numbers in this assay, from the lowest: compound 2; then compounds 3 and 1 (each within the scatter of the next).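

In this assay the swap of ethyl for methylsulfanyl, on an aromatic carbon meta to a large group, gives a number 6 percentage points lower from compound 1 to compound 3 (within the scatter) and so separates the two groups by no more than repeated measurements would. For the compounds shown here, this is the first pair here that differs in one place only, and it shows that, at this position, a sulfur atom can stand in the group attached to the ring without a step beyond the scatter, with the heavy-atom count unchanged. Nothing available here accounts for the closeness of the two results.

As far as these compounds go, whether a longer chain, an amine or a carboxylic acid at this position would leave the response equally close remains open. So does whether the swap from 3-ethylphenyl to 3-(methylsulfanyl)phenyl would give a similar step on a different core, since only this one pair shows it.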